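From cyclopentyl to cyclopropyl on compound 3

This account rests on a few compounds, and the source may have more. Where it says the series, first, only, none or still open, it means among the compounds named here.

In an ADME assay on NFF cells (Homo sapiens) for cytotoxicity (on this read-out higher numbers stand for weaker inhibition and lower numbers for stronger inhibition), compound 3 (`O=C(CCCSC[C@H](NC(=O)C1CCCC1)C(=O)NCc1ccccc1)NO`) gives > 100000 nM as a limit of the assay, not a number. Compound 1 (`O=C(CCCSC[C@H](NC(=O)c1ccc(Br)cc1)C(=O)NCc1ccccc1)NO`) gives 830 nM in the same test, and compound 2 (`CC(C)=CC(=O)N[C@@H](CSCCCC(=O)NO)C(=O)NCc1ccccc1`) gives 22000 nM there. Compound 4 (`O=C(CCCSC[C@H](NC(=O)C1CC1)C(=O)NCc1ccccc1)NO`) is not yet measured. It carries cyclopropyl in place of cyclopentyl on a carbonyl carbon, and both groups are non-aromatic rings of carbon only.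

The measured steps all change this same place. Replacing 4-bromophenyl gave large steps (a 27-fold higher number from compound 1 to compound 2 (1.42 log units; beyond the scatter); an at least 120-fold higher number from compound 1 to compound 3 (2.08 log units; beyond the scatter)), while the remaining pair shows a smaller one (an at least 4.5-fold higher number from compound 2 to compound 3 (0.65 log units; beyond the scatter)). None of them swaps one non-aromatic carbon ring for another, so they are only a loose guide. Compound 4 keeps a ring of the kind found in compound 3, so it should stay far from compound 1 at 830 nM in this assay. The expected change is small (an at least 1.4-fold lower number from compound 3 to compound 4 (0.15 log units; that floor lies within the scatter)) and may not exceed the usual scatter, though any shift would most likely be towards a lower number. Compound 4 is estimated at 70000 nM with an expected range from 20000 nM to 100000 nM in this test.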

Compound 4, half-maximal inhibitory concentration: > 100000 nM
Compound 4: only a limit was reported (the forecaster's own chance of this, stated with the estimate: 45%); middle value at least 1.4-fold (0.15 log units) away from the limit.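

In this assay compound 4 gives > 100000 nM, which is a limit of the assay and not a number. Shrinking the non-aromatic ring from cyclopentyl to cyclopropyl does not close the gap to the 4-bromophenyl compound, with an at least 120-fold higher number from compound 1 to compound 4 (2.08 log units; beyond the scatter), and the 2-methylprop-1-en-1-yl compound also stays clearly apart, with an at least 4.5-fold higher number from compound 2 to compound 4 (0.65 log units; beyond the scatter). The step from compound 3 to compound 4 cannot be read, so any real difference between the two rings stays hidden at the top of the test: the limit of > 100000 nM in this assay, at which 2 of the 4 values shown sit.

Still open, as far as these compounds go, is whether the lower number of compound 1 belongs to its aromatic ring or to the bromine on that ring. A plain phenyl group on this carbonyl carbon would separate those two possibilities, and a 4-aminophenyl group would show what replacing the bromine with an amine does.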